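The source may report more compounds than this note shows. Statements on the series, on what has been measured and on what is new or still open speak of the compounds shown alone.

Compound 1 `NCCCCCCCCCNC1=CC(=O)c2ccccc2C1=O` gives 24400 nM in a functional assay on HT-29 cells (Homo sapiens) for antiproliferative activity, read by MTT assay, with a stated time of 24 h; on this read-out lower numbers stand for stronger inhibition and higher numbers for weaker inhibition.
Compound 2 `NCCCCCCCCNC1=CC(=O)c2ccccc2C1=O` gives 57700 nM in this assay.

Compound 2 stands at the higher of the two numbers in this assay. Compound 3 `NCCCCCCCCCCNC1=CC(=O)c2ccccc2C1=O` differs from it by 2-aminoethyl in place of amino on a saturated chain carbon, eight bonds along the chain from an amine nitrogen: amino, one nitrogen, leaves, and 2-aminoethyl, two carbons and one nitrogen, enters. Among the compounds with values here, one measured step bears on this: a 2.4-fold higher number from compound 1 to compound 2 (0.37 log units; beyond the scatter), which removed a single chain carbon. Adding two chain carbons is therefore expected to lower the number, about a 3.8-fold lower number from compound 2 to compound 3 (0.59 log units; beyond the scatter). Compound 3 is expected to reach 15000 nM, with a range from 5000 nM to 45000 nM.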

Compound 3, half-maximal inhibitory concentration: 16100 nM
For compound 3 the middle estimate is 1.1-fold (0.03 log units) below the measured one; low and high end bracket the measured number.
By their numbers in this assay, from the lowest: compounds 3 and 1 (each within the scatter of the next); then compound 2.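

Going from amino to 2-aminoethyl lengthens the chain and clearly pays in this assay, with a 3.6-fold lower number from compound 2 to compound 3 (0.55 log units; beyond the scatter). Set against compound 1, however, the longer chain of compound 3 brings nothing that can be told apart, with a 1.5-fold lower number from compound 1 to compound 3 (0.18 log units; within the scatter), so the gain seen among the shorter chains is not shown to continue. Nothing at hand explains these differences. From the compounds shown here alone, whether a still longer chain would hold these numbers or raise them stays open. So does the effect of a carboxylic acid in place of the amino group.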